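This account rests on a few compounds, and the source may have more. Where it says the series, first, only, none or still open, it means among the compounds named here.

Compound 1 `Cc1nc(C(=O)Nc2ccc(Cl)c(-c3nnc4c(Cl)cccn34)c2)cs1`: > 100000 nM
Compound 2 `O=C(Nc1ccc(Cl)c(-c2nnc3c(Cl)cccn23)c1)c1cccc(Cl)c1`: 71900 nM

Compound 1 sits at the limit of > 100000 nM in this assay, at which 1 of the 2 values shown sits. In a functional assay on MCF7 cells (Homo sapiens) for antiproliferative activity, read by MTT assay, with a stated time of 72 h (on this read-out higher numbers stand for weaker inhibition and lower numbers for stronger inhibition), compound 1 gives > 100000 nM, which is a limit of the assay and not a number. In this assay compound 2 gives 71900 nM. Among the compounds with values here, the one measured step, an at least 1.3-fold lower number from compound 1 to compound 2 (0.14 log units; that floor lies within the scatter), exchanges the group on the carbonyl carbon for a substituted phenyl and gives only a floor for the change.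

Compound 3 `O=C(Nc1ccc(Cl)c(-c2nnc3c(Cl)cccn23)c1)c1c(F)cccc1Cl` differs from compound 1 by 2-chloro-6-fluorophenyl in place of 2-methyl-1,3-thiazol-4-yl on a carbonyl carbon. Within the data shown here, this is the only step that bears on it, and it carries a second halogen on the phenyl in place of the single one of compound 2. With only a floor to go on, the expected step from compound 1 is small and downward in number, about an at least 1.4-fold lower number from compound 1 to compound 3 (0.15 log units; that floor lies within the scatter), with a real chance that the assay again reports only a limit. Compound 3 is therefore estimated at 70000 nM in this assay, within a range from 30000 nM to 150000 nM.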

Compound 3, half-maximal inhibitory concentration: > 100000 nM
Compound 3 ended at the assay's limit (the forecaster's own chance of this, stated with the estimate: 40%); middle value at least 1.4-fold (0.15 log units) away from the limit.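

At this position on the carbonyl carbon, a phenyl ring does not by itself keep a compound within the readable range of this assay: compound 3 carries one, as compound 2 does, yet it ends at a limit of the assay, as compound 1 does, and the position now shows this: the limit of > 100000 nM in this assay, at which 2 of the 3 values shown sit. Placing 2-chloro-6-fluorophenyl where compound 2 has 3-chlorophenyl gives an at least 1.3-fold higher number from compound 2 to compound 3 (0.14 log units; that floor lies within the scatter), so these two phenyl groups are not told apart. The step between compound 1 and compound 3 cannot be read, with a limit at both ends.

Left open is how far compound 1 and compound 3 lie past that limit. Also open, from the compounds shown here alone, is whether another group on this carbonyl carbon, such as an unsubstituted phenyl, a piperidine ring or a carboxylic acid, would give a clearly lower number.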